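This account rests on a few compounds, and the source may have more. Where it says the series, first, only, none or still open, it means among the compounds named here.

Values in a physicochemical assay for lipophilicity, read by HPLC, at pH 7.5 (on this read-out lower numbers stand for lower lipophilicity and higher numbers for higher lipophilicity), so far:
Compound 1 `CC[C@@H](Nc1c(C#N)c(-c2ccc(-c3ncccc3C)cc2)nc2cnccc12)C(N)=O` gives 2
Compound 2 `CC[C@@H](Nc1c(C#N)c(-c2ccc(-c3cccc(Cl)c3OC)cc2)nc2cnccc12)C(N)=O` gives 3.1
Compound 3 `CCOc1ccccc1-c1ccc(-c2nc3cnccc3c(N[C@H](CC)C(N)=O)c2C#N)cc1` gives 3

The step of a number 0.10 log units lower from compound 2 to compound 3 (within the scatter) lies within the scatter, so those two values cannot be told apart. The step of a number 1.00 log units higher from compound 1 to compound 3 (beyond the scatter) lies beyond it, as does the step of a number 1.10 log units higher from compound 1 to compound 2 (beyond the scatter) of similar size. Compound 3 therefore stands in the upper pair of the three numbers.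

Compound 4 `CC[C@@H](Nc1c(C#N)c(-c2ccc(Br)cc2)nc2cnccc12)C(N)=O` is still unmeasured. The change leading to it is bromo in place of 2-ethoxyphenyl on an aromatic carbon with bromo in place of 2-ethoxyphenyl on an aromatic carbon, para to a large group. All three measured steps exchange the group at this same place, but none replaces it with a halogen, so they guide the size only loosely. The entering group has no ring, and compound 1 with 2 shows that the number can sit well down with another group here, so a lower number is expected, without direct precedent in the data.

In this assay the estimated step is a number 0.50 log units lower from compound 3 to compound 4 (beyond the scatter) and this would be a moderate fall beyond the scatter. The expected value for compound 4 is 2.5 with an estimated range from 2 to 3 on this scale.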

Compound 4, distribution coefficient: 2.2
The estimate for compound 4 lay 0.30 log units above the measured number; measured number inside the range.
By their numbers in this assay, from the lowest: compounds 1 and 4 (each within the scatter of the next); then compounds 3 and 2 (each within the scatter of the next).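

Working notes on the series: in this assay bromo in place of 2-ethoxyphenyl gives a number 0.80 log units lower from compound 3 to compound 4 (beyond the scatter) and bromo in place of 3-chloro-2-methoxyphenyl gives a number 0.90 log units lower from compound 2 to compound 4 (beyond the scatter) so a single bromine at this position, with no ring, falls clearly under both substituted phenyl compounds. Bromo in place of 3-methylpyridin-2-yl gives a number 0.20 log units higher from compound 1 to compound 4 (within the scatter) and the two cannot be told apart, so the presence of a ring at this position does not by itself set the number, since compound 1 carries a ring and compound 4 does not. No measured evidence on the origin of these steps is available.

The compounds shown leave open where an unsubstituted phenyl, a methyl group or a longer alkyl chain would fall at this position, and so whether the high pair owes its place to the benzene ring or to its substituents. On these data alone, an amine or a carboxylic acid here also remains open, as does whether these steps would hold with another group in place of the nitrile on the shared core.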